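This account rests on a few compounds, and the source may have more. Where it says the series, first, only, none or still open, it means among the compounds named here.

Measured so far:
compound 1 `N#CC1=C(N)Oc2cc3oc(-c4ccccc4)cc(=O)c3c(O)c2C12C(=O)N(Cc1ccccc1)c1c(Cl)cccc12`: in a functional assay on A549 cells (Homo sapiens) for antiproliferative activity, read by MTT assay, with a stated time of 48 h (on this read-out higher numbers stand for weaker inhibition and lower numbers for stronger inhibition), compound 1 gives > 50000 nM, which is a limit of the assay rather than a number.
compound 2 `N#CC1=C(N)Oc2cc3oc(-c4ccccc4)cc(=O)c3c(O)c2C12C(=O)Nc1ccccc12`: in this assay compound 2 gives 37600 nM.

Compound 2 thus holds the only number shown. Compound 1 sits at the limit of > 50000 nM in this assay, at which 1 of the 2 values shown sits. No step between measured compounds is shown.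

Compound 3 `N#CC1=C(N)Oc2cc3oc(-c4ccccc4)cc(=O)c3c(O)c2C12C(=O)Nc1c(Cl)cccc12` differs from compound 2 by chloro in place of hydrogen on an aromatic carbon. Within the data shown here, no measured step gives a size for this change. In this assay no step beyond the scatter is expected in either direction, with a fair chance that compound 3 returns only a limit. Compound 3 is expected at 45000 nM, between 20000 nM and 100000 nM. The expected step is a 1.2-fold higher number from compound 2 to compound 3 (0.08 log units; within the scatter).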

Compound 3, half-maximal inhibitory concentration: > 50000 nM
Compound 3 gave a limit, no number; the forecaster's own chance of this, stated with the estimate: 45%; at least 1.1-fold (0.04 log units) between middle value and limit.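

In this assay compound 3 gives > 50000 nM, which is a limit of the assay and not a number. On these data alone, the step that can be read is an at least 1.3-fold higher number from compound 2 to compound 3 (0.12 log units; that floor lies within the scatter), so chloro in place of hydrogen on this aromatic carbon gives no sign of stronger inhibition, while its true size stays unknown. The step between compound 1 and compound 3 cannot be read, and the series now reads mostly as limits: the limit of > 50000 nM in this assay, at which 2 of the 3 values shown sit.

As far as these compounds go, whether fluoro, methoxy or an amine on this aromatic carbon would give a readable number remains open. Also open, from the compounds shown here alone, is how benzyl on the amide-type nitrogen acts without the chloro.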